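Replacing a Fluorophenyl with an Acetamidothiazole on the Sulfonamide

The source may hold more compounds than are shown below. What is called first, only, known or untested is meant among the compounds shown, and "the series" means these compounds.

Of the compounds shown here, three share one core and have been measured in an ADME assay (liver) for metabolic stability, with Liver microsome (Homo sapiens) as the target, read by LC-MS, using microsomes and NADPH, with a stated time of 5 min, at 37 degrees C; a lower number here means slower removal, a higher number faster removal of the compound. Compound 1 `CCn1c([C@@H](C)NS(=O)(=O)c2ccc(Cl)cc2)nc2ccccc21` gives > 100 mL.min-1.g-1 in this assay, which is a limit of the assay rather than a number. Compound 2 `CCn1c([C@@H](C)NS(=O)(=O)c2ccc(Cl)cc2)nc2ccc(CN(C)C)cc21`, carrying a (dimethylamino)methyl group on the core, gives 30 mL.min-1.g-1. Compound 3 `CCn1c([C@@H](C)NS(=O)(=O)c2ccc(F)cc2)nc2ccc(C(F)(F)F)cc21` gives 26 mL.min-1.g-1, and the values of compound 2 and compound 3 lie within the scatter of each other, so no order can be read between them.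

Among the measured compounds shown here, the only measured step is an at least 3.3-fold lower number from compound 1 to compound 2 (0.52 log units; beyond the scatter). That step sits on the core, not on the sulfonyl side of the molecule, so it does not speak directly to the change now at hand. Compound 4 `CCn1c([C@@H](C)NS(=O)(=O)c2cnc(NC(C)=O)s2)nc2ccc(C(F)(F)F)cc21` differs from compound 3 in one place: 2-acetamido-1,3-thiazol-5-yl in place of 4-fluorophenyl on a sulfonyl sulfur. For the measured compounds named here, no measured pair shows what a change on the sulfonyl sulfur does in this assay, and the pair of compound 2 and compound 3, which differ in two places, shows only that their values are within the scatter.

With nothing measured that bears on this position, compound 4 is expected to give 22 mL.min-1.g-1, somewhere between 8 mL.min-1.g-1 and 60 mL.min-1.g-1. The step this implies, a 1.2-fold lower number from compound 3 to compound 4 (0.07 log units; within the scatter), is an estimate, not a measurement.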

Compound 4, intrinsic clearance in microsomes: 15 mL.min-1.g-1
Estimate against measurement, compound 4: 1.5-fold (0.17 log units) above; the range from low to high includes it.
By their numbers in this assay, from the lowest: compounds 4, 3 and 2 (each within the scatter of the next). At a limit, above all of these: compound 1.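

Among the compounds shown here, the first measured change on the sulfonyl sulfur gives, in this assay, a 1.7-fold lower number from compound 3 to compound 4 (0.24 log units; within the scatter). The step shows that 4-fluorophenyl can give way to 2-acetamido-1,3-thiazol-5-yl, a different ring that brings a hydrogen-bond donor and hydrogen-bond acceptors, without a change in removal by liver microsomes that can be told apart from the ordinary spread of repeated measurements. Nothing given here bears on why the swap leaves the number within that spread.

From the compounds shown here alone, this rests on a single pair, both members of which carry trifluoromethyl on the shared core, so it remains open whether the same exchange would behave alike on the core with the (dimethylamino)methyl group of compound 2. Going by these compounds, it also remains open whether a free amine or a carboxylic acid in place of the acetamido group, or a longer chain on the amide, would move the number beyond the scatter in either direction, which would show how much this position can really take.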